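The source may report more compounds than this note shows. Statements on the series, on what has been measured and on what is new or still open speak of the compounds shown alone.

Measured compounds so far:
- compound 1, `CC(=O)c1sc(NC(C)C)c(C#N)c1N`: in an assay for inhibition of Maternal embryonic leucine zipper kinase (Homo sapiens), read by ADP-Glo, with a stated time of 0.5 h (a lower number here means a stronger inhibitor, a higher number a weaker inhibitor), compound 1 gives > 5000 nM, a limit of the assay rather than a number.
- compound 2, `CC(C)Nc1sc(C(=O)c2ccncc2)c(N)c1C#N`: in this assay compound 2 gives > 5000 nM, again a limit and not a number.
- compound 3, `CC(C)Nc1sc(C(=O)c2ccc(Br)s2)c(N)c1C#N`: in this assay compound 3 gives 122 nM.

Compound 1 therefore stands only at a limit, and it shares that position with one other member of the set (the limit of > 5000 nM in this assay, at which 2 of the 3 values shown sit). The step to the next compound, compound 4, `CC(C)Nc1sc(C(=O)c2cc(Br)cs2)c(N)c1C#N`, is the following change: 4-bromothiophen-2-yl in place of methyl on a carbonyl carbon. Among the compounds with values here, two measured steps bear on it. The closest is an at least 40-fold lower number from compound 1 to compound 3 (1.61 log units; beyond the scatter), where a bromothiophenyl group of the same kind, differing only in the name of its bromine substitution, replaces the methyl on the carbonyl carbon and produces a large drop. The same outcome is seen in an at least 40-fold lower number from compound 2 to compound 3 (1.61 log units; beyond the scatter). By contrast a step that the two limits leave unreadable from compound 1 to compound 2 cannot be read, as both ends sit at a limit. Within the data shown here, no measured pair separates a 4-bromothiophen-2-yl from a 5-bromothiophen-2-yl, so the size of any difference between the two is unknown. A large step in the same direction as the step to compound 3 is expected, an at least 20-fold lower number from compound 1 to compound 4 (1.30 log units; beyond the scatter), with a wider range to allow for the changed bromine placement. Compound 4 is estimated at 250 nM, within 60 nM to 1500 nM.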

Compound 4, half-maximal inhibitory concentration: 599 nM
Compound 4: middle estimate off by 2.4-fold (0.38 log units), on the low side; the measured number falls inside the stated range.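

In this assay, within the data shown here, the first measured pair that separates the two bromine placements on the thiophene ring shows that the placement matters, with 4-bromothiophen-2-yl in place of 5-bromothiophen-2-yl on the carbonyl carbon giving a 4.9-fold higher number from compound 3 to compound 4 (0.69 log units; beyond the scatter). The 4-bromothiophen-2-yl group still improves on the methyl, with an at least 8.3-fold lower number from compound 1 to compound 4 (0.92 log units; beyond the scatter), and on the pyridin-4-yl group, with an at least 8.3-fold lower number from compound 2 to compound 4 (0.92 log units; beyond the scatter), so the gain over those two groups does not belong to the 5-bromothiophen-2-yl group alone. Both of these steps start from a limit and not a number, so they give only a bound on their size: the limit of > 5000 nM in this assay, at which 2 of the 4 values shown sit.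

The compounds shown leave open whether the bromine is needed at all, a question that a plain thiophen-2-yl or a 5-chlorothiophen-2-yl group on the carbonyl carbon would address. Going by these compounds, all four compounds also carry the same isopropylamino group on the shared core, so the effect of a cyclopropylamine or a longer alkyl chain in its place remains unknown.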